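Chlorothiophene swap on compound 3: working notes

A few compounds are considered here, and "the series" means these few. Any claim that something is new, unique, unknown or untested is made for them only; others in the source may bear on it.

In a functional assay on DU-145 cells (Homo sapiens) for cytotoxicity, read by ELISA, with a stated time of 4 days (a lower number here means a stronger inhibitor, a higher number a weaker inhibitor), the measured compounds read as follows:
compound 1 `Cc1ccsc1-c1cc(-c2ccco2)cc(-c2ccc(Cl)cc2)n1` gives 26700 nM
compound 2 `Cc1ccsc1-c1cc(-c2ccc(Cl)o2)cc(-c2ccco2)n1` gives 27300 nM
compound 3 `Cc1ccsc1-c1cc(-c2ccc(Cl)o2)cc(-c2ccc(Cl)cc2)n1` gives 21900 nM

Compound 3 has the lowest of the three numbers, but it lies within the scatter of both others, so the three are not separated. The next step leads to compound 4 `Clc1ccc(-c2cc(-c3ccc(Cl)o3)cc(-c3ccc(Cl)s3)n2)cc1` and is 5-chlorothiophen-2-yl in place of 3-methylthiophen-2-yl on an aromatic carbon. In words, 5-chlorothiophen-2-yl stands in place of 3-methylthiophen-2-yl on an aromatic carbon, next to the ring nitrogen.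

Two measured steps give the nearest guide: a 1.2-fold lower number from compound 1 to compound 3 (0.09 log units; within the scatter) for chloro in place of hydrogen, and a 1.2-fold lower number from compound 2 to compound 3 (0.10 log units; within the scatter) for 4-chlorophenyl in place of furan-2-yl. Both are within the scatter, but both lie at other places on the core. Among the compounds with values here, all three measured compounds keep 3-methylthiophen-2-yl, so this site has no measured step of its own. The step expected in this assay is a 1.2-fold lower number from compound 3 to compound 4 (0.09 log units; within the scatter) and so none beyond the scatter, though with a wide margin. In this assay the estimated value for compound 4 is 18000 nM (expected range 7000 nM to 40000 nM).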

Compound 4, half-maximal inhibitory concentration: 23000 nM
The estimate for compound 4 lay 1.3-fold (0.11 log units) below the measured number, within the range that was stated.
By their numbers in this assay, from the lowest: compounds 3, 4, 1 and 2 (each within the scatter of the next).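

The position next to the ring nitrogen now has a step of its own: in this assay, 5-chlorothiophen-2-yl in place of 3-methylthiophen-2-yl gives a 1.1-fold higher number from compound 3 to compound 4 (0.02 log units; within the scatter), so this exchange of one substituted thiophene for another does not separate the two compounds. With the other groups of compound 3 held fixed, the 3-methylthiophen-2-yl group is therefore not needed to keep the number within the scatter of compound 3. No supporting measurement is available to explain this result.

Still open, from the compounds shown here alone, is whether an amine or a carboxylic acid at this position, in place of the thiophene, would move the number beyond the scatter. Also open, going by these compounds, is whether the same thiophene exchange would read alike with the furan-2-yl group of compound 1 or compound 2 on the core.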